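Thioamide versus amide on a pyridazinone side chain

This account rests on a few compounds, and the source may have more. Where it says the series, first, only, none or still open, it means among the compounds named here.

Of the compounds shown here, three sharing one core have been tested in a functional assay on the whole organism (stomach) for inhibition, with Rattus norvegicus as the target, at a dose of 100 mg/kg by the intraduodenal route; on this read-out lower numbers stand for less inhibition and higher numbers for more inhibition at the one dose given (going by the name of the read-out). Compound 1 `N#CCCn1nc(-c2ccccc2)ccc1=O` gives 10.1%. Compound 2 `C/N=C(\S)CCn1nc(-c2ccccc2)ccc1=O` gives 68.2%. Compound 3 `CNC(=O)CCn1nc(-c2ccccc2)ccc1=O` gives 3.5%, the lowest of the three; its gap to compound 1 lies within the scatter, while compound 2 stands far above it.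

Compound 4 `N=C(S)CCCCCn1nc(-c2ccccc2)ccc1=O` is the next step. Its change from compound 3 is a group of 6 heavy atoms (4 carbon, 1 nitrogen, 1 sulfur; no ring) in place of a group of 4 heavy atoms (2 carbon, 1 nitrogen, 1 oxygen; no ring), on a saturated chain carbon, two bonds along the chain from an aromatic nitrogen. The group that leaves carries oxygen; the group that enters carries sulfur and is longer by two carbons, with a second hydrogen-bond donor.

Going by the values given here, two measured steps bear on this. The sulfur-for-oxygen exchange was seen in reverse as a number 64.7 percentage points lower from compound 2 to compound 3 (beyond the scatter), and the arrival of the sulfur group as a number 58.1 percentage points higher from compound 1 to compound 2 (beyond the scatter). Both point to a large rise in this assay when sulfur enters. Among the compounds with values here, the longer chain and the missing methyl have no counterpart among the measured compounds, so the size is less certain.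

Compound 4 is therefore expected to give 45%, within 15% to 75%, an estimated a number 41.5 percentage points higher from compound 3 to compound 4 (beyond the scatter).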

Compound 4, a percentage reported as inhibition, in the whole organism at one dose (the size of the read-out at that dose, not a potency): 91.4%
Compound 4: the middle estimate sits 46.4 percentage points below what was measured; the measured number lies above the stated range.
By their numbers in this assay, from the lowest: compounds 3 and 1 (each within the scatter of the next); then compound 2; then compound 4.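

In this assay, the longer sulfur-bearing group of compound 4 goes further than the shorter one, with a number 23.2 percentage points higher from compound 2 to compound 4 (beyond the scatter), so this place on the chain takes a longer sulfur-bearing group with no loss of inhibition. The steps from the two groups without sulfur are larger, with a number 87.9 percentage points higher from compound 3 to compound 4 (beyond the scatter) and a number 81.3 percentage points higher from compound 1 to compound 4 (beyond the scatter), and among these compounds both sulfur-bearing groups stand well clear of the nitrile and the methylcarbamoyl. Nothing measured here explains these differences.

On these data alone, the step from the shorter sulfur-bearing group to the longer one adds chain length and drops the methyl together, so the share of each stays unknown. Also open, as far as these compounds go, is how the oxygen amide on the longer chain, a still longer chain or a carboxylic acid in this place would behave.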